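A few compounds are considered here, and "the series" means these few. Any claim that something is new, unique, unknown or untested is made for them only; others in the source may bear on it.

In an ADME assay on cells (Mus musculus, strain Balb/c) for cytotoxicity, read by MTT assay, with a stated time of 48 h (a higher number here means that more compound is tolerated, a lower number that less compound is tolerated), compound 1 `COc1ccc(C(/C=C/c2cccs2)=N/O)cc1` gives 10600 nM, and compound 2 `O/N=C(\C=C\c1cccs1)c1ccc(Cl)cc1` gives 11800 nM. Compound 2 holds the larger of the two numbers, yet the step of a 1.1-fold higher number from compound 1 to compound 2 (0.05 log units; within the scatter) stays within the scatter, so the two compounds are not distinguished. Compound 3 `O/N=C(\C=C\c1cccs1)c1ccc(Br)cc1` differs from compound 2 by bromo in place of chloro on an aromatic carbon. Going by the values given here, the only measured step, chloro in place of methoxy on an aromatic carbon, was small, and a further halogen exchange at that aromatic carbon is expected to give no step beyond the scatter, a 1.0-fold lower number from compound 2 to compound 3 (0.01 log units; within the scatter). Compound 3 is therefore estimated at 11500 nM, with a range from 6500 nM to 21000 nM.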

Compound 3, half-maximal cytotoxic concentration: 15400 nM
For compound 3 the middle estimate is 1.3-fold (0.13 log units) below the measured one; measured number inside the range.
By their numbers in this assay, from the lowest: compounds 1, 2 and 3 (each within the scatter of the next).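

At this place, on an aromatic carbon para to a large group, bromo in place of chloro gives a 1.3-fold higher number from compound 2 to compound 3 (0.12 log units; within the scatter), and bromo in place of methoxy gives a 1.5-fold higher number from compound 1 to compound 3 (0.16 log units; within the scatter). A second halogen thus leaves this assay unmoved beyond the scatter, and methoxy, chloro and bromo are not told apart here. Nothing available explains these small steps. The compounds shown leave open whether an amine or a carboxylic acid at this place would give a step beyond the scatter. They also leave open what a change elsewhere on the shared core would do.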